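Swapping Substituent Positions on the Urea Aryl Ring

This account rests on a few compounds, and the source may have more. Where it says the series, first, only, none or still open, it means among the compounds named here.

Compound 1, `CC1CN(C(=O)c2ccc(-c3ccc(NC(=O)Nc4ccc(Cl)c(C(F)(F)F)c4)cc3)cc2)CC(C)O1`: 2050 nM in a functional assay on HT-29 cells (Homo sapiens) for inhibition, read by MTT assay, with a stated time of 120 h; on this read-out higher numbers stand for weaker inhibition and lower numbers for stronger inhibition
Compound 2, `O=C(CCc1ccc(NC(=O)Nc2ccc(Cl)c(C(F)(F)F)c2)cc1)NC1CCC1`: 21300 nM
Compound 3, `CC(NC(=O)c1ccc(-c2ccc(NC(=O)Nc3ccc(Cl)c(C(F)(F)F)c3)cc2)cc1)c1ccccc1`: 5960 nM

Among the three measured compounds, compound 1 gives the lowest number in this assay. Compound 3 lies nearest to it, with a step of a 2.9-fold higher number from compound 1 to compound 3 (0.46 log units; beyond the scatter), and compound 2 sits furthest away, a gap well beyond the scatter. Among the measured compounds shown here, the only measured step, a 2.9-fold higher number from compound 1 to compound 3 (0.46 log units; beyond the scatter), alters the group on the carbonyl carbon at the far end of the shared core; it says nothing directly about the ring carried by the urea nitrogen.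

Compound 4, `CC1CN(C(=O)c2ccc(-c3ccc(NC(=O)Nc4cc(C(F)(F)F)ccc4Cl)cc3)cc2)CC(C)O1`, differs from compound 1 only by 2-chloro-5-(trifluoromethyl)phenyl in place of 4-chloro-3-(trifluoromethyl)phenyl on an amide-type nitrogen. For the measured compounds named here, no measured step touches this part of the molecule, so neither the size nor the direction of the change can be read from the numbers at hand, and the expectation must carry a wide range. Compound 4 is expected to give 4500 nM, within a range from 1500 nM to 15000 nM. That estimate corresponds to an expected step of a 2.2-fold higher number from compound 1 to compound 4 (0.34 log units; beyond the scatter), a modest move toward weaker inhibition that could well fall within the scatter.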

Compound 4, half-maximal inhibitory concentration: 1900 nM
For compound 4 the middle estimate is 2.4-fold (0.37 log units) above the measured one, and the stated range covers the measured number.
By their numbers in this assay, from the lowest: compounds 4 and 1 (each within the scatter of the next); then compound 3; then compound 2.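

With 2-chloro-5-(trifluoromethyl)phenyl in place of 4-chloro-3-(trifluoromethyl)phenyl on an amide-type nitrogen, this assay records a 1.1-fold lower number from compound 1 to compound 4 (0.03 log units; within the scatter). Among the compounds shown here, this is the first reading on the ring carried by the urea nitrogen, and it shows that, on the core of compound 1, this read-out does not separate these two arrangements of the same atoms. The data at hand offer no explanation for this result.

As far as these compounds go, whether the same exchange would read alike alongside the (1-phenylethyl)amino group of compound 3 remains open. Also open, from the compounds shown here alone, is what a nitrile or a methoxy group in place of the chlorine, or a hydrogen in place of the trifluoromethyl, would do to the number on this ring.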